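The source may report more compounds than this note shows. Statements on the series, on what has been measured and on what is new or still open speak of the compounds shown alone.

This account follows one change within a small set of sulfonamides that share a common core. Compound 1 `O=C1NCCN1c1ccc(S(=O)(=O)Nc2ccc3[nH]ccc3c2)cc1`, compound 2 `O=C1NCCN1c1ccc(S(=O)(=O)Nc2ccccc2)cc1` and compound 3 `CC(C)(C)c1cc(NS(=O)(=O)c2ccc(N3CCNC3=O)cc2)cc(C(C)(C)C)c1` have been measured; compound 4 `COc1ccc(NS(=O)(=O)c2ccc(N3CCNC3=O)cc2)cc1` has not. In a functional assay on M21 cells (Homo sapiens) for antiproliferative activity, read by sulforhodamine B assay, with a stated time of 48 h (on this read-out higher numbers stand for weaker inhibition and lower numbers for stronger inhibition), compound 1 gives 87 nM. In this assay compound 2 gives 200 nM, the higher of the two numbers recorded, and the gap that separates it from compound 1 lies beyond the usual scatter of repeated measurements. For compound 3 this assay reports only a limit, > 1000 nM, which is not a number. Within the data shown here, compound 3 is the one value that sits at the limit of > 1000 nM in this assay, at which 1 of the 3 values shown sits.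

Compound 4 differs from compound 2 in a single place: methoxy in place of hydrogen on an aromatic carbon. Among the measured compounds shown here, no pair of measured compounds mirrors this change, so nothing among the recorded values gives its direction. The step from compound 2 to compound 4 is expected to amount to a 1.3-fold lower number from compound 2 to compound 4 (0.12 log units; within the scatter), that is, no shift beyond the scatter in either direction. Compound 4 is therefore estimated to give 150 nM in this assay, within a range from 60 nM to 450 nM.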

Compound 4, half-maximal inhibitory concentration: 580 nM
Compound 4: middle estimate off by 3.9-fold (0.59 log units), on the low side; measured number outside the range, above it.
By their numbers in this assay, from the lowest: compound 1; then compound 2; then compound 4. At a limit, above all of these: compound 3.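

In this assay, the change from phenyl to 4-methoxyphenyl gives a 2.9-fold higher number from compound 2 to compound 4 (0.46 log units; beyond the scatter), so this aromatic carbon, para to a large group, is a place where substitution moves the number beyond the scatter. Among these compounds, this is the first one-place comparison in the set, and it gives the direction that no earlier pair could supply: with methoxy in place of hydrogen, inhibition becomes modestly weaker. The finding holds for this single group at this single place, and no listed step connects it to compound 1 or compound 3, so it cannot be extended to either of them.

The data shown contain nothing that bears on why the number rises at this position. On these data alone, it also remains open whether the rise is specific to methoxy or would also appear with another group on the same carbon, such as fluorine, an amine, a carboxylic acid or a longer alkoxy chain, and whether any of these would instead bring the number down from that of compound 2.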